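Moving One Hydroxy Group Around an Aromatic Ring

The source may report more compounds than this note shows. Statements on the series, on what has been measured and on what is new or still open speak of the compounds shown alone.

Going by the values given here, in a functional assay on SW-620 cells (Homo sapiens) for inhibition, read by sulforhodamine B assay, with a stated time of 48 h (on this read-out lower numbers stand for stronger inhibition of growth and higher numbers for weaker inhibition of growth), compound 1 `O=C(Cc1csc2nc(-c3ccc(Br)cc3)cn12)N/N=C/c1ccccc1` gives 18600 nM, while compound 2 `O=C(Cc1csc2nc(-c3ccc(Br)cc3)cn12)N/N=C/c1ccccc1O` gives 3980 nM, the lower of the two numbers so far. Compound 3 `O=C(Cc1csc2nc(-c3ccc(Br)cc3)cn12)N/N=C/c1ccc(O)cc1` has the same atoms as compound 2, joined differently: 4-hydroxyphenyl in place of 2-hydroxyphenyl on a carbon with a double bond to nitrogen. Among the compounds with values here, the only measured step bearing on this is a 4.7-fold lower number from compound 1 to compound 2 (0.67 log units; beyond the scatter), where the hydroxy group was gained. Whether that gain survives the move is unmeasured, so a partial loss is expected, an estimated 1.6-fold higher number from compound 2 to compound 3 (0.21 log units; within the scatter). Compound 3 is estimated at 6500 nM, with an expected range of 2500 nM to 17000 nM.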

Compound 3, concentration for 50% growth inhibition: 31600 nM
The estimate for compound 3 lay 4.9-fold (0.69 log units) below the measured number; measured number above the stated range.
By their numbers in this assay, from the lowest: compound 2; then compounds 1 and 3 (each within the scatter of the next).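

With 4-hydroxyphenyl in place of 2-hydroxyphenyl on the carbon with a double bond to nitrogen, the result is a 7.9-fold higher number from compound 2 to compound 3 (0.90 log units; beyond the scatter) and so the same atoms, joined differently, do not read the same. Set against the ring without a hydroxy group, the result is a 1.7-fold higher number from compound 1 to compound 3 (0.23 log units; within the scatter) and so the gain seen with 2-hydroxyphenyl does not carry over to 4-hydroxyphenyl. Nothing available explains this difference. Still open, on these data alone, is whether a methoxy group or an amine in place of the hydroxy group would keep the gain seen with 2-hydroxyphenyl.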